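Swapping dimethylamino for methyl on the shared core

The compounds below may be only part of what the source reports. "The series", "measured", "known", "first", "only" and "open" are said of these compounds alone.

Compound 1 `CSc1ncnc2c1c(-c1ccoc1)cn2[C@@H]1O[C@H](CO)[C@@H](O)[C@H]1O`: 360 nM
Compound 2 `CNc1ncnc2c1c(-c1ccoc1)cn2[C@@H]1O[C@H](CO)[C@@H](O)[C@H]1O`: > 15000 nM (a limit of the assay, not a number)
Compound 3 `CN(C)c1ncnc2c1c(-c1ccoc1)cn2[C@@H]1O[C@H](CO)[C@@H](O)[C@H]1O`: 1160 nM

These compounds share one core and differ in a single group, and all were tested in a functional assay on HL-60 cells (Homo sapiens) for antiproliferative activity, read by XTT assay, with a stated time of 72 h; on this read-out lower numbers stand for stronger inhibition and higher numbers for weaker inhibition. Among the compounds with values here, only two of the values are true numbers. Of these, compound 3 has the higher, 1160 nM, and its nearest neighbour is compound 1 at 360 nM.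

The next compound is compound 4 `Cc1ncnc2c1c(-c1ccoc1)cn2[C@@H]1O[C@H](CO)[C@@H](O)[C@H]1O`, which carries methyl in place of dimethylamino on an aromatic carbon. Within the data shown here, no measured step makes this exact exchange, so the expectation has to lean on its neighbours. The closest is a 3.2-fold higher number from compound 1 to compound 3 (0.51 log units; beyond the scatter), where dimethylamino replaced methylsulfanyl. The two large steps, an at least 41-fold higher number from compound 1 to compound 2 (1.61 log units; beyond the scatter) and an at least 12-fold lower number from compound 2 to compound 3 (1.11 log units; beyond the scatter), both involve compound 2. They show how strongly this assay responds to the group at this place, but they do not give a size for this exchange.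

Read backwards, the modest step of a 3.2-fold higher number from compound 1 to compound 3 (0.51 log units; beyond the scatter) suggests that losing dimethylamino may lower the number by a similar modest amount. The expected change is a 2.9-fold lower number from compound 3 to compound 4 (0.46 log units; beyond the scatter). Compound 4 is estimated at 400 nM, with an expected range from 80 nM to 2000 nM.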

Compound 4, half-maximal inhibitory concentration: > 15000 nM
Compound 4: only a limit was reported; the forecaster's own chance of this, stated with the estimate: 8%; middle value at least 37-fold (1.57 log units) from the limit.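

In this assay the change to methyl gives an at least 12-fold higher number from compound 3 to compound 4 (1.11 log units; beyond the scatter) and also an at least 41-fold higher number from compound 1 to compound 4 (1.61 log units; beyond the scatter) as its second readable step. Within the data shown here, until now, compound 2 was the only compound to reach the limit of the assay, so the loss could have been tied to methylamino alone and to the hydrogen on its nitrogen. Methyl has no nitrogen and 0 hydrogen-bond donors, so that hydrogen is not required for the loss, and among the groups shown at this place on the shared core, only methylsulfanyl and dimethylamino give true numbers.

These compounds leave open whether the true numbers depend on something that methylsulfanyl and dimethylamino have in common, which groups such as methoxy, ethyl or a longer chain like propyl could help to test. Whether compound 4 is weaker than compound 2 or the other way round cannot be read, since the values of both compounds are limits and not numbers: the limit of > 15000 nM in this assay, at which 2 of the 4 values shown sit.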